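Swapping 2-fluorophenyl for 3-chlorophenyl on a shared core

The source may report more compounds than this note shows. Statements on the series, on what has been measured and on what is new or still open speak of the compounds shown alone.

In a functional assay on A549 cells (Homo sapiens) for inhibition, read by MTT assay, with a stated time of 48 h (on this read-out higher numbers stand for weaker inhibition and lower numbers for stronger inhibition), compound 3 `Nc1n[nH]c2cccc(-c3cccc(NC(=O)Nc4ccccc4F)c3)c12` gives 1170 nM. Compound 1 `CC(C)c1cccc(NC(=O)Nc2cccc(-c3cccc4[nH]nc(N)c34)c2)c1` gives 1420 nM, and these two values lie within the scatter of each other. Compound 2 `Nc1n[nH]c2cccc(-c3cccc(NC(=O)Nc4nccs4)c3)c12` reads > 500000 nM, which is a limit of the assay and not a number.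

The next compound, compound 4 `Nc1n[nH]c2cccc(-c3cccc(NC(=O)Nc4cccc(Cl)c4)c3)c12`, keeps the shared core and puts 3-chlorophenyl in place of 2-fluorophenyl on an amide-type nitrogen.

Within the data shown here, three measured steps bear on this change. The two large ones, an at least 350-fold higher number from compound 1 to compound 2 (2.54 log units; beyond the scatter) and an at least 420-fold lower number from compound 2 to compound 3 (2.63 log units; beyond the scatter), both involve 1,3-thiazol-2-yl and rest on a limit: the limit of > 500000 nM in this assay, at which 1 of the 3 values shown sits. Compound 4 carries no such group, so these steps offer little guidance. The closer parallel is a swap between two groups that each contain a six-membered aromatic ring of carbon only, a 1.2-fold lower number from compound 1 to compound 3 (0.08 log units; within the scatter), and it stays within the scatter. On that evidence, no step beyond the scatter is expected in this assay, and the expected change is a 1.1-fold higher number from compound 3 to compound 4 (0.05 log units; within the scatter). Compound 4 is estimated at 1300 nM, with an expected range from 500 nM to 3500 nM.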

Compound 4, half-maximal inhibitory concentration: 1720 nM
Estimate against measurement, compound 4: 1.3-fold (0.12 log units) below; measured number inside the range.
By their numbers in this assay, from the lowest: compounds 3, 1 and 4 (each within the scatter of the next). At a limit, above all of these: compound 2.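

In this assay, among these compounds, 3-chlorophenyl in place of 2-fluorophenyl on the amide-type nitrogen is a 1.5-fold higher number from compound 3 to compound 4 (0.17 log units; within the scatter), so changing the halogen and its printed ring position together produces no step that stands clear of the scatter. The earlier compounds shown here had not compared chloro with isopropyl, and this single swap on an aromatic carbon is a 1.2-fold higher number from compound 1 to compound 4 (0.08 log units; within the scatter). Compounds 1, 3 and 4 now form a set of three groups with a six-membered aromatic ring of carbon only, all within the scatter of each other, and compound 2, with 1,3-thiazol-2-yl, goes against that picture, as an at least 290-fold lower number from compound 2 to compound 4 (2.46 log units; beyond the scatter) shows, a step that rests on a limit of the assay and not on a number: the limit of > 500000 nM in this assay, at which 1 of the 4 values shown sits.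

The compounds shown leave open whether the sharp loss belongs to 1,3-thiazol-2-yl alone or to other rings that are not made of carbon only, such as pyridin-3-yl. They also leave open how far this tolerance reaches, for instance with unsubstituted phenyl, a plain butyl chain on the nitrogen, or a phenyl ring carrying a carboxylic acid or an amine.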